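Replacing Nitro with Chloro on Compound 3

The compounds below may be only part of what the source reports. "The series", "measured", "known", "first", "only" and "open" are said of these compounds alone.

Of the compounds shown here, three with a shared core have been tested in a functional assay on MCF7 cells (Homo sapiens) for cytotoxicity, read by sulforhodamine B assay; a higher number here means a weaker inhibitor of growth, a lower number a stronger inhibitor of growth: compound 1 `CC1=CC[C@@H]([C@@](C)(O)CCCC(C)(C)NC(=S)N/N=C\c2ccc(C)cc2)CC1`, compound 2 `CC1=CC[C@@H]([C@@](C)(O)CCCC(C)(C)NC(=S)N/N=C\c2ccccc2[N+](=O)[O-])CC1` and compound 3 `CC1=CC[C@@H]([C@@](C)(O)CCCC(C)(C)NC(=S)N/N=C\c2cccc([N+](=O)[O-])c2)CC1`. Compound 1 reads > 100000 nM, which is a limit of the assay and not a number. Compound 2 reads > 100000 nM, which is also a limit. Only compound 3 gives an actual number, 18300 nM, and that makes it the strongest growth inhibitor of the three.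

Compound 4 `CC1=CC[C@@H]([C@@](C)(O)CCCC(C)(C)NC(=S)N/N=C\c2cccc(Cl)c2)CC1` makes one change to compound 3: chloro in place of nitro on an aromatic carbon, meta to a large group (chloro in place of nitro on an aromatic carbon). This exact swap has not been measured, so the closest guides are the other changes to the same aromatic group. These are an at least 5.4-fold lower number from compound 2 to compound 3 (0.73 log units; beyond the scatter) and an at least 5.4-fold lower number from compound 1 to compound 3 (0.73 log units; beyond the scatter). Each is only a minimum size, since one end is a limit. Both show that this part of the molecule matters, and that the 3-nitrophenyl version alone gave a number in this assay. Losing the nitro group therefore seems more likely to raise the number than to lower it, though probably not by a large step. The expected change is a 2.2-fold higher number from compound 3 to compound 4 (0.34 log units; beyond the scatter). For compound 4 the estimated value is 40000 nM, with an expected range of 12000 nM to 100000 nM.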

Compound 4, concentration for total growth inhibition: 19500 nM
Estimate against measurement, compound 4: 2.1-fold (0.31 log units) above, within the range that was stated.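

In this assay, chloro, with 1 heavy atom and no hydrogen-bond acceptors, stands in for nitro, with 3 heavy atoms and 2 hydrogen-bond acceptors, and the result is a 1.1-fold higher number from compound 3 to compound 4 (0.03 log units; within the scatter), so the two groups cannot be told apart at this position. The measurable growth inhibition of compound 3 is therefore not tied to the nitro group, and the 3-chlorophenyl version also stands clear of the other two aromatic groups, with an at least 5.1-fold lower number from compound 2 to compound 4 (0.70 log units; beyond the scatter) and an at least 5.1-fold lower number from compound 1 to compound 4 (0.70 log units; beyond the scatter). These two steps are only minimum sizes because compound 1 and compound 2 each read as a limit of the assay and not as a number: the limit of > 100000 nM in this assay, at which 2 of the 4 values shown sit.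

As far as these compounds go, it remains open whether a quite different group at this position, such as an amine or a carboxylic acid, would also give a number in this assay. From the compounds shown here alone, it is also open whether the group or its place on the ring decides the outcome, a question that a 3-methylphenyl or a 4-nitrophenyl version would help to answer.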